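A few compounds are considered here, and "the series" means these few. Any claim that something is new, unique, unknown or untested is made for them only; others in the source may bear on it.

Measured so far in an in vitro assay on BHK cells for displacement of a labelled ligand from Glucagon receptor (Homo sapiens), read by scintillation proximity assay; on this read-out lower numbers stand for stronger inhibition and higher numbers for weaker inhibition:
compound 1 `O=C(O)CCNC(=O)c1ccc(CN(c2ccc3c(c2)CCCC3)c2nc(-c3ccc(Cl)c(Cl)c3)cs2)cc1`, 79 nM
compound 2 `Cc1cc(N(Cc2ccc(C(=O)NCCC(=O)O)cc2)c2nc(-c3ccc(C(F)(F)F)cc3)cs2)ccc1C(C)C`, 119 nM
compound 3 `O=C(O)CCNC(=O)c1ccc(CC(c2ccc(Cl)cc2)c2nc(-c3ccc(OC(F)(F)F)cc3)cs2)cc1`, 153 nM

Compound 2 sits with the second highest of the three numbers; its nearest neighbour is compound 3 and its furthest is compound 1, and both of those gaps lie within the usual scatter of this assay. Among the measured compounds shown here, the three measured compounds therefore give no separation that could be read as a trend, and no single-point step between any two of them is available.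

Compound 4 `O=C(O)CCNC(=O)c1ccc(CN(c2ccc(SC(F)(F)F)cc2)c2nc(-c3ccc(C(F)(F)F)cc3)cs2)cc1` is not yet measured. It differs from compound 2 in one place: 4-((trifluoromethyl)sulfanyl)phenyl in place of 4-isopropyl-3-methylphenyl on a nitrogen on an aromatic ring. The rest of the molecule, including the shared core and the acid-bearing side chain, is unchanged.

For the measured compounds named here, with no measured step that isolates this exchange on the nitrogen, nothing in the data points in either direction. The working expectation is a step from compound 2 to compound 4 of about a 1.3-fold lower number from compound 2 to compound 4 (0.12 log units; within the scatter), which is no more than the scatter, with the estimate for compound 4 put at 90 nM and a range from 35 nM to 250 nM.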

Compound 4, half-maximal inhibitory concentration: 34 nM
Compound 4: the middle estimate sits 2.6-fold (0.42 log units) above what was measured; measured number outside the range, below it.
By their numbers in this assay, from the lowest: compound 4; then compounds 1, 2 and 3 (each within the scatter of the next).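

In this assay, among the compounds shown here, the group on the nitrogen on an aromatic ring is the first place where a single exchange gives a step beyond the scatter: a 3.5-fold lower number from compound 2 to compound 4 (0.54 log units; beyond the scatter). The number therefore responds to the group at this position, and the 4-isopropyl-3-methylphenyl group is not needed for binding, since 4-((trifluoromethyl)sulfanyl)phenyl gives the lower number with the rest of the molecule unchanged. No available evidence explains this step.

This single exchange removes the isopropyl and methyl groups and adds the (trifluoromethyl)sulfanyl group together, so their separate contributions cannot be read from it. On these data alone, it also remains open how a nitrile or an amine in place of the (trifluoromethyl)sulfanyl group would read, and whether the step carries over to other groups on the shared core.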